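A Saturated Ring Replaces a Thiadiazole on the Amine

The source may report more compounds than this note shows. Statements on the series, on what has been measured and on what is new or still open speak of the compounds shown alone.

The three measured compounds share one core. Compound 1 `CNc1nc2ccccc2c(=O)o1` carries methyl on a nitrogen on an aromatic ring, compound 2 `O=c1oc(Nc2cc(Cl)ccc2Cl)nc2ccccc12` carries a dichlorophenyl group there, and compound 3 `O=c1oc(Nc2nncs2)nc2ccccc12` carries 1,3,4-thiadiazol-2-yl. In an assay on isolated protein for inhibition of complement C1r subcomponent (Homo sapiens) (a lower number here means a stronger inhibitor, a higher number a weaker inhibitor), compound 2 gives 2000 nM. For compound 1 the assay reports only a limit, > 62500 nM. For compound 3 as well only a limit is reported, > 62500 nM. Compound 3 thus stands at the weak end of the numbers shown, sitting at the limit of > 62500 nM in this assay, at which 2 of the 3 values shown sit, and no number places it against compound 2. The step that the two limits leave unreadable from compound 1 to compound 3 is left unreadable by the two limits.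

Compound 4 `O=c1oc(NC2CCSC2)nc2ccccc12` differs from compound 3 in one place: thiolan-3-yl in place of 1,3,4-thiadiazol-2-yl on a nitrogen on an aromatic ring. For the measured compounds named here, no measured step bears directly on this change, since the only measured step, from compound 1 to compound 3, has no readable size. Going by the values given here, the sole numeric value, that of compound 2, belongs to a substituent unlike either ring. Compound 4 is therefore expected to remain weak, and the step of an at least 1.5-fold lower number from compound 3 to compound 4 (0.19 log units; that floor lies within the scatter) is an estimate with no readable anchor. The estimate for compound 4 is 40000 nM, expected to fall between 8000 nM and 100000 nM.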

Compound 4, half-maximal inhibitory concentration: > 62500 nM
Compound 4: only a limit was reported; the forecaster's own chance of this, stated with the estimate: 60%; at least 1.5-fold (0.19 log units) between middle value and limit.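

In this assay compound 4 gives > 62500 nM, which is a limit and not a number, so neither the step to compound 4 from compound 3 nor that from compound 1 can be read. Compound 4 stands with the others at this end: the limit of > 62500 nM in this assay, at which 3 of the 4 values shown sit.

The compounds shown leave open whether thiolan-3-yl and 1,3,4-thiadiazol-2-yl differ at all in this assay.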